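This account rests on a few compounds, and the source may have more. Where it says the series, first, only, none or still open, it means among the compounds named here.

Measured compounds:
Compound 1 `COc1cccc2c1c(NS(=O)(=O)c1ccc(Cl)s1)nn2Cc1cccc(CNC(=O)C2COC2)c1` gives 20 nM in a functional assay on CHO cells for antagonist activity at C-C chemokine receptor type 4 (Homo sapiens), read by GTPgammaS binding; a lower number here means a stronger inhibitor, a higher number a weaker inhibitor.
Compound 2 `COc1cccc2c1c(NS(=O)(=O)c1ccc(Cl)s1)nn2Cc1cccc(CNC(=O)C2CCCO2)c1` gives 39.8 nM in this assay.

For the measured compounds named here, compound 2 stands with the higher of the two numbers so far, its nearest neighbour being compound 1; the step of a 2.0-fold higher number from compound 1 to compound 2 (0.30 log units; within the scatter) lies within the scatter, so the two compounds cannot be told apart on these numbers. Compound 3 `COc1cccc2c1c(NS(=O)(=O)c1ccc(Cl)s1)nn2Cc1cccc(CNC(=O)C2CCOCC2)c1` has not yet been measured. It differs from compound 2 in a single place: oxan-4-yl in place of oxolan-2-yl on a carbonyl carbon. Going by the values given here, the only measured step that bears on this change is a 2.0-fold higher number from compound 1 to compound 2 (0.30 log units; within the scatter), which also exchanged one non-aromatic ring with one hetero atom for another on the same carbonyl carbon and stayed within the scatter. A further exchange of the same kind, now to a six-membered non-aromatic ring with one hetero atom, is therefore expected to give a number close to that of compound 2, with no step beyond the scatter in either direction. For compound 3 the expected step is a 1.1-fold lower number from compound 2 to compound 3 (0.06 log units; within the scatter). The estimate for compound 3 in this assay is 35 nM, with a range from 15 nM to 90 nM.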

Compound 3, half-maximal inhibitory concentration: 31.6 nM
Compound 3: middle estimate off by 1.1-fold (0.04 log units), on the high side; measured number inside the range.
By their numbers in this assay, from the lowest: compounds 1, 3 and 2 (each within the scatter of the next).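

The exchange of oxolan-2-yl for oxan-4-yl on the carbonyl carbon gives a 1.3-fold lower number from compound 2 to compound 3 (0.10 log units; within the scatter) in this assay, and the exchange of oxetan-3-yl for oxan-4-yl gives a 1.6-fold higher number from compound 1 to compound 3 (0.20 log units; within the scatter) as the second step read here. For the compounds shown here, the earlier pair covered only one exchange of ring, whereas these steps extend the result to a six-membered non-aromatic ring with 1 hetero atom: oxetan-3-yl, oxolan-2-yl and oxan-4-yl on this carbonyl carbon cannot be told apart in this assay, although the ring size and the point of attachment both differ among them. Nothing measured here accounts for this flat result, and no supporting data on the compounds are available.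

All three groups are non-aromatic rings whose single hetero atom is oxygen, so the compounds leave open whether the number would hold with cyclohexyl, which has no ring oxygen, or with piperidin-4-yl, which has a ring nitrogen in its place. They also say nothing about a carboxylic acid or an open chain such as methoxyethyl on the same carbonyl carbon.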